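The source may report more compounds than this note shows. Statements on the series, on what has been measured and on what is new or still open speak of the compounds shown alone.

Two compounds built on the core of compound 1, `O=C1C=C(Nc2ccc(Cl)cc2)CCC1`, have so far been tested in an assay on isolated protein for inhibition of cytochrome c oxidase subunit 2 (Homo sapiens), read by ELISA, with a stated time of 2 min, tested at 10 uM; on this read-out lower numbers stand for less inhibition and higher numbers for more inhibition at the one concentration tested (going by the name of the read-out). Compound 1 gives 88.6%. Compound 2, `O=C1C=C(Nc2ccc([N+](=O)[O-])cc2)CCC1`, gives 24.2%. Within the data shown here, the single measured step between them, a number 64.4 percentage points lower from compound 1 to compound 2 (beyond the scatter), is the only comparison available. Compound 2 therefore stands at the lowest of the two numbers recorded, with compound 1 as its nearest neighbour, well beyond the scatter above it.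

The next compound, compound 3, `CC(=O)c1ccc(NC2=CC(=O)CCC2)cc1`, has not yet been measured in this assay. It differs from compound 2 in one place: acetyl in place of nitro on an aromatic carbon. Among the measured compounds shown here, the only measured step that bears on this change is the earlier exchange of one group for another at the same aromatic carbon, and that step was large. A single step cannot say whether acetyl will sit nearer to the chloro of compound 1 or to the nitro of compound 2, so the expectation is broad. Compound 3 is expected to give about 45%, somewhere between 15% and 80%. This corresponds to an expected upward step of a number 20.8 percentage points higher from compound 2 to compound 3 (beyond the scatter), though a result within the scatter would not surprise.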

Compound 3, a percentage reported as inhibition, at one concentration (the size of the read-out at that concentration, not a potency): 41.9%
Compound 3: middle estimate off by 3.1 percentage points, on the high side, and the stated range covers the measured number.
By their numbers in this assay, from the lowest: compound 2; then compound 3; then compound 1.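

In this assay the exchange of nitro for acetyl, on the aromatic carbon para to a group of 8 heavy atoms, gives a number 17.7 percentage points higher from compound 2 to compound 3 (beyond the scatter) and so shows that this position responds to more than the single contrast seen before, with a modest recovery from the nitro level rather than a return to the chloro level. Set against the chloro group, acetyl gives a number 46.7 percentage points lower from compound 1 to compound 3 (beyond the scatter) and this step is clearly the larger of the two, so acetyl stands closer to nitro than to chloro, and the three groups at this one carbon now give three separate levels, with chloro highest and each gap beyond the scatter. No measurement here accounts for this order of the three groups.

Among these compounds, with only three groups on this carbon, it remains open where an amine, a methoxy group, a carboxylic acid or a smaller halogen such as fluoro would fall relative to chloro, and whether anything at this position exceeds it. As far as these compounds go, it is equally open whether the same order of chloro, acetyl and nitro would hold on another carbon of the aromatic ring or with a change elsewhere in the shared core.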